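This account rests on a few compounds, and the source may have more. Where it says the series, first, only, none or still open, it means among the compounds named here.

Measured so far in an assay on CHO cells for displacement of a labelled ligand from adenosine receptor A3 (Homo sapiens), tested at 10 uM; on this read-out lower numbers stand for less inhibition and higher numbers for more inhibition at the one concentration tested (going by the name of the read-out):
compound 1, `Nc1sc2cnccc2c1C(=O)c1ccccc1`, gives 0%;
compound 2, `Nc1sc2cnccc2c1C(=O)c1ccc(Cl)cc1`, gives 0%;
compound 3, `Nc1sc2cnccc2c1C(=O)c1ccccc1Cl`, gives 0%.

All three share one core and differ only in what sits on the aromatic ring attached to the carbonyl. On these numbers compound 1 stands level with compounds 2 and 3: the step of no change at the digits printed from compound 1 to compound 2 (within the scatter) and the step of no change at the digits printed from compound 1 to compound 3 (within the scatter) both lie within the scatter, so adding a chloro at either position left the read-out where it was.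

Compound 4, `Nc1sc2cnccc2c1C(=O)c1ccc(Br)cc1`, has not yet been measured. It differs from compound 1 in one place: bromo in place of hydrogen on an aromatic carbon. The closest guide is no change at the digits printed from compound 1 to compound 2 (within the scatter), where a chloro entered para to a large group, and no change at the digits printed from compound 1 to compound 3 (within the scatter) carries the same message from another position. Nothing measured here shows any halogen raising inhibition, so no step beyond the scatter is expected in this assay.

Compound 4 is therefore expected to give 0%, within a range from 0% to 10%. That estimate means an expected step of no change at the digits printed from compound 1 to compound 4 (within the scatter), nothing beyond the scatter.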

Compound 4, a percentage reported as inhibition, at one concentration (the size of the read-out at that concentration, not a potency): 0%
Beside the measured number, compound 4's estimate shows no gap at the digits printed, within the range that was stated.
By their numbers in this assay, from the lowest: compounds 1, 2, 3 and 4 (each within the scatter of the next).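

In this assay, a bromo on an aromatic carbon para to a large group reads the same as hydrogen (no change at the digits printed from compound 1 to compound 4 (within the scatter)). Exchanging chloro for bromo at that position also makes no difference (no change at the digits printed from compound 2 to compound 4 (within the scatter)). The earlier compounds showed this only for chloro, so two halogens now leave the read-out at the same level here, and no measurement at hand explains that result.

As far as these compounds go, it remains open whether any group at this position can lift the inhibition above that of compound 1 (0%), since only halogens have been compared with hydrogen here. An amine, a carboxylic acid or a longer chain at this position might behave differently, as might a change to the shared core itself.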